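Three Anilide Limits and a Dichlorophenyl Question

The compounds below may be only part of what the source reports. "The series", "measured", "known", "first", "only" and "open" are said of these compounds alone.

Compound 1, `O=C(COc1ccc(/C=C2\SC(=O)NC2=O)cc1)Nc1cccc([N+](=O)[O-])c1`, gives a limit of > 100000 nM in a functional assay on KB cells (Homo sapiens) for inhibition; on this read-out lower numbers stand for stronger inhibition of growth and higher numbers for weaker inhibition of growth.
Compound 2, `O=C(COc1ccc(/C=C2\SC(=O)NC2=O)cc1)Nc1ccc(F)cc1`, gives a limit of > 100000 nM in this assay.
Compound 3, `Cc1cc(Br)ccc1NC(=O)COc1ccc(/C=C2\SC(=O)NC2=O)cc1`, gives a limit of > 100000 nM in this assay.

Compound 3 stands where every measured compound in this set stands: the limit of > 100000 nM in this assay, at which 3 of the 3 values shown sit. For compound 3 the read-out in this assay is a limit and not a number, so its place among the others cannot be ranked. The three measured steps, a step that the two limits leave unreadable from compound 1 to compound 2, a step that the two limits leave unreadable from compound 1 to compound 3 and a step that the two limits leave unreadable from compound 2 to compound 3, are all unreadable in size and direction; each swaps the group on the amide-type nitrogen and each ends at the same limit.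

Compound 4, `O=C(COc1ccc(/C=C2\SC(=O)NC2=O)cc1)Nc1c(Cl)cccc1Cl`, differs from compound 3 in exactly that place: 2,6-dichlorophenyl in place of 4-bromo-2-methylphenyl on an amide-type nitrogen. All three measured steps bear on this kind of change, and none of them shows a readable movement in growth inhibition. No basis exists for expecting a shift beyond the scatter in either direction. In this assay compound 4 is therefore expected to give 100000 nM, within a range from 30000 nM to 300000 nM. The estimated step from compound 3 to compound 4 is a number no higher from compound 3 to compound 4 (the limit leaves the size open), most likely reported once more only as a limit.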

Compound 4, concentration for 50% growth inhibition: > 100000 nM
Compound 4 was reported as a limit (the forecaster's own chance of this, stated with the estimate: 85%); the middle value lies on the limit itself.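

In this assay compound 4 gives > 100000 nM, which is a limit and not a number. Its steps from compound 1, compound 2 and compound 3 therefore cannot be read: the limit of > 100000 nM in this assay, at which 4 of the 4 values shown sit. The compounds shown leave open whether any group on the amide-type nitrogen gives a readable number in this assay.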